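A few compounds are considered here, and "the series" means these few. Any claim that something is new, unique, unknown or untested is made for them only; others in the source may bear on it.

Measured so far:
compound 1, `Cc1c(C(=O)c2cccc(CN(C)C)c2)oc2cc(-c3ccccc3)cc(O)c12`: 0.09 ug/mL
compound 2, `COc1ccc(CCOC(=O)c2oc3cc(-c4ccccc4)cc(O)c3c2C)cc1`: 0.02 ug/mL
compound 3, `Cc1c(C(=O)c2cnc3ccccc3c2)oc2cc(-c3ccccc3)cc(O)c12`: > 4 ug/mL

In a functional assay on WI-38 VA13 cells (Homo sapiens) for cytotoxicity (a lower number here means that less compound is needed, a higher number that more compound is needed for the effect), compound 2 gives 0.02 ug/mL, the lowest of the two numbers shown. The nearest number is that of compound 1, which in this assay gives 0.09 ug/mL, a gap that lies beyond the usual scatter. In this assay compound 3 gives > 4 ug/mL, which is a limit of the assay and not a number. That entry of compound 3 is the limit of > 4 ug/mL in this assay, at which 1 of the 3 values shown sits.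

Compound 4, `COc1ccc(CCOC(=O)c2oc3cc(-c4ccccc4)cc(O)c3c2C)cc1OC`, has not yet been measured. It differs from compound 2 in one place: methoxy in place of hydrogen on an aromatic carbon. Read one bond further out, the change is 4-methoxyphenyl to 3,4-dimethoxyphenyl on the ester side of the shared core. Within the data shown here, no pair of measured compounds shows a step of this kind, so there is nothing to say how far the number should move. The expectation is a step from compound 2 to compound 4 of a 1.5-fold higher number from compound 2 to compound 4 (0.18 log units; within the scatter), that is, a change in this assay not beyond the scatter and in no firm direction. Compound 4 is therefore estimated at 0.03 ug/mL in this assay, with a range from 0.01 ug/mL to 0.1 ug/mL.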

Compound 4, half-maximal effective concentration: 0.021 ug/mL
Beside the measured number, compound 4's estimate is 1.4-fold (0.15 log units) above it; measured number inside the range.
By their numbers in this assay, from the lowest: compounds 2 and 4 (each within the scatter of the next); then compound 1. At a limit, above all of these: compound 3.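

In this assay, among these compounds, methoxy in place of hydrogen gives a 1.1-fold higher number from compound 2 to compound 4 (0.02 log units; within the scatter), the first single change that can be read. On this aromatic carbon, ortho to a methoxy group, the change from 4-methoxyphenyl to 3,4-dimethoxyphenyl leaves compound 2 and compound 4 within the scatter of each other, so this read-out does not tell them apart. Nothing at hand bears on why the step has this size.

Open, going by these compounds, is whether this aromatic carbon tolerates a group other than methoxy, such as an amine, a carboxylic acid or a longer chain like butoxy. With a single pair, the result also says nothing about methoxy at other places on this ring or on a ring carrying no methoxy group.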